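Working notes: from compound 2 to compound 3

The source may report more compounds than this note shows. Statements on the series, on what has been measured and on what is new or still open speak of the compounds shown alone.

Among the compounds with values here, compound 1 `CC(C)Cn1c(=O)n(C)c(=O)c2c1nc(Cc1cccc3ccccc13)c(=O)n2CCCCO` is the only member of this set with a number: in an assay on MCF7 cells for inhibition of Monocarboxylate transporter 1 (Homo sapiens), read by scintillation counting, with a stated time of 10 min (on this read-out higher numbers stand for weaker inhibition and lower numbers for stronger inhibition), compound 1 gives 548 nM. Compound 2 `CC(C)Cn1c(=O)n(C)c(=O)c2nc(S(=O)(=O)CCCO)c(Cc3cccc4ccccc34)nc21` carries the (3-hydroxypropyl)sulfonyl group and was run in this assay, where compound 2 is reported as "not determined" (no result reported), so compound 2 stands nowhere on the numbers shown. Compound 3 `CC(C)Cn1c(=O)n(C)c(=O)c2nc(/C=C\CCCO)c(Cc3cccc4ccccc34)nc21` differs from compound 2 by 5-hydroxypent-1-en-1-yl in place of (3-hydroxypropyl)sulfonyl on an aromatic carbon. Within the data shown here, with no value for compound 2 and no step between measured compounds, no direction for the move from compound 2 to compound 3 in this assay can be read off; a step within the scatter, or one beyond it in either direction, remains equally open, and its size cannot be set from the data. Compound 3 is expected to give 1000 nM in this assay, within a range of 200 nM to 5000 nM. This expectation rests on compound 1, which gives 548 nM and is the single measured point available.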

Compound 3, half-maximal inhibitory concentration: 116 nM
Compound 3: middle estimate off by 8.6-fold (0.94 log units), on the high side; the measured number lies below the stated range.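

Within the data shown here, compound 2 has no number in this assay and compound 3 gives 116 nM there, so no step from compound 2 to compound 3 can be read. No evidence shown bears on this result. Going by these compounds, how the 5-hydroxypent-1-en-1-yl and (3-hydroxypropyl)sulfonyl groups compare on this read-out stays open.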